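Methoxy for Hydroxy on a Second Core

The compounds below may be only part of what the source reports. "The series", "measured", "known", "first", "only" and "open" are said of these compounds alone.

Compound 1 `O=C(Nc1cccc(-n2cc(-c3ccncc3)c(-c3cc(O)cc(Cl)c3)n2)c1)Nc1ccc(Cl)c(C(F)(F)F)c1` and compound 2 `COc1cc(Cl)cc(-c2nn(-c3cccc(NC(=O)Nc4ccc(Cl)c(C(F)(F)F)c4)c3)cc2-c2ccncc2)c1` share one core; compound 3 `O=C(Nc1cccc(-n2cc(-c3ccncc3)c(-c3cc(O)cc(Cl)c3)n2)c1)c1cc(C(F)(F)F)cc(C(F)(F)F)c1` and compound 4 `COc1cc(Cl)cc(-c2nn(-c3cccc(NC(=O)c4cc(C(F)(F)F)cc(C(F)(F)F)c4)c3)cc2-c2ccncc2)c1` share another, and the difference between the two cores is not broken down here. In a functional assay on SW-620 cells (Homo sapiens) for inhibition, read by sulforhodamine B assay, with a stated time of 48 h, tested at 10 uM (a higher number here means a weaker effect of the compound at the concentration tested, a lower number a stronger effect), compound 1 gives -33.6% and compound 2 gives 12.7%; the change methyl in place of hydrogen on an oxygen on an aromatic ring made a step of a number 46.3 percentage points higher from compound 1 to compound 2 (beyond the scatter). Compound 3 gives 61% in this assay. The change from compound 3 to compound 4 is the same, (methyl in place of hydrogen on an oxygen on an aromatic ring), at a place described in the same words. Because the step of a number 46.3 percentage points higher from compound 1 to compound 2 (beyond the scatter) weakened the effect and compound 3 already starts weak, the expected step for compound 4 is a smaller one, a number 25 percentage points higher from compound 3 to compound 4 (beyond the scatter). Compound 4 is therefore estimated at 86%, between 65% and 105%.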

Compound 4, a percentage reported as activity, at one concentration (the size of the read-out at that concentration, not a potency): 86.2%
For compound 4 the middle estimate is 0.2 percentage points below the measured one; the measured number falls inside the stated range.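

On the second core, methoxy in place of hydroxy again moved the read-out in the same direction in this assay, with a number 25.2 percentage points higher from compound 3 to compound 4 (beyond the scatter), so the direction of the change carried over from one core to the other. The size of the step did not carry over: the same change on two cores in this assay, a number 46.3 percentage points higher (beyond the scatter) from compound 1 to compound 2 and a number 25.2 percentage points higher (beyond the scatter) from compound 3 to compound 4, 21.1 percentage points apart, beyond the scatter of two such steps

This is a single comparison between two cores, so it does not show which part of the difference between those cores goes with the gap, or how the change would behave on a third core. The compounds shown leave open what other groups at this oxygen would give in this assay, such as an ethyl or a longer chain, and what an amine in place of the hydroxy would give.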